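Sulfonamide series: aryl change on the sulfonyl sulfur

The source may hold more compounds than are shown below. What is called first, only, known or untested is meant among the compounds shown, and "the series" means these compounds.

Compound 1: `C=Cc1ccc(S(=O)(=O)Nc2ccc3oc(-c4ccccc4)nc3c2)cc1`; in an assay on isolated protein for inhibition of malate dehydrogenase, mitochondrial (Sus scrofa), with stated times of 45 min and 30 min (on this read-out lower numbers stand for stronger inhibition and higher numbers for weaker inhibition), compound 1 gives > 63000 nM, a limit of the assay.
Compound 2: `O=S(=O)(Nc1ccc2oc(-c3ccccc3)nc2c1)c1cccc(Cl)c1`; in this assay compound 2 gives > 63000 nM, again a limit.

Compound 2 thus stands at the assay limit; no number is known for it, and the same holds for compound 1, so that the step that the two limits leave unreadable from compound 1 to compound 2 cannot be read in either direction or size. Both values sit at the limit of > 63000 nM in this assay, at which 2 of the 2 values shown sit.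

Compound 3 is `COc1ccccc1S(=O)(=O)Nc1ccc2oc(-c3ccccc3)nc2c1`. It differs from compound 2 by 2-methoxyphenyl in place of 3-chlorophenyl on a sulfonyl sulfur. For the measured compounds named here, the only measured step, from compound 1 to compound 2, also changes the aryl group on the sulfonyl sulfur and is unreadable because of the limit of > 63000 nM in this assay, at which 2 of the 2 values shown sit. Going by the values given here, no measured step therefore bears on the change to compound 3 with a readable size, and there is nothing to suggest a move beyond the scatter in this assay.

Compound 3 is expected to give about 100000 nM, with a range from 30000 nM to 300000 nM. The estimated step from compound 2 to compound 3, a step that the limit leaves unreadable from compound 2 to compound 3, is expected to be no more than scatter, and a limit rather than a number is the likely outcome.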

Compound 3, half-maximal inhibitory concentration: > 63000 nM
Compound 3 was reported as a limit; the forecaster's own chance of this, stated with the estimate: 80%; the middle value lies beyond the limit too.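

Compound 3 joins compound 1 and compound 2 at a limit of this assay, and no new step can be read among the three: the limit of > 63000 nM in this assay, at which 3 of the 3 values shown sit.

Going by these compounds, whether any aryl group on the sulfonyl sulfur of the shared core gives a readable inhibition, and how large a step between such groups would be, remains open.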